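Piperidine to pyrrolidinyl-propanol on a decylphenyl oxadiazole

The compounds below may be only part of what the source reports. "The series", "measured", "known", "first", "only" and "open" are said of these compounds alone.

Measured so far in an assay on HeLa cells for inhibition of sphingosine-1-phosphate transporter SPNS2 (Mus musculus), read by LC-MS, tested at 2 uM; on this read-out lower numbers stand for less inhibition and higher numbers for more inhibition at the one concentration tested (going by the name of the read-out):
Compound 1 `CCCCCCCCCCc1ccc(-c2noc(C3CCNCC3)n2)cc1` gives 66%.
Compound 2 `CCCCCCCCCCc1ccc(-c2noc(CC[C@@H](N)C(=O)O)n2)cc1` gives 5%.
Compound 3 `CCCCCCCCCCc1ccc(-c2noc(C(Cl)CCN)n2)cc1` gives 5%.

Compound 3 is level with compound 2 at the digits shown, and together they are the lowest of the three numbers; compound 1 is far higher, as the step of a number 61 percentage points lower from compound 1 to compound 3 (beyond the scatter) shows, while no change at the digits printed from compound 2 to compound 3 (within the scatter) is within the scatter.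

Compound 4 `CCCCCCCCCCc1ccc(-c2noc(CC(O)CN3CCCC3)n2)cc1` differs from compound 3 by a group of 9 heavy atoms (7 carbon, 1 nitrogen, 1 oxygen; one five-membered non-aromatic ring with 1 hetero atom) in place of a group of 5 heavy atoms (3 carbon, 1 nitrogen, 1 chlorine; no ring), on an aromatic carbon. Within the data shown here, the only measured compound that carries a nitrogen within a non-aromatic ring is compound 1, which gives 66%; compound 4 also carries such a ring, so a rise is expected, though compound 2 and compound 3 show that other chains give little inhibition. Compound 4 is therefore estimated at 35%, between 10% and 65%, an expected step of a number 30 percentage points higher from compound 3 to compound 4 (beyond the scatter).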

Compound 4, a percentage reported as inhibition, at one concentration (the size of the read-out at that concentration, not a potency): 21%
Compound 4: the middle estimate sits 14 percentage points above what was measured; the range from low to high includes it.
By their numbers in this assay, from the lowest: compounds 2 and 3 (each within the scatter of the next); then compound 4; then compound 1.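

Among these compounds, the 2-hydroxy-3-(pyrrolidin-1-yl)propyl group is the first at this position, apart from piperidin-4-yl, to give a gain beyond the scatter over the low compounds (a number 16 percentage points higher from compound 3 to compound 4 (beyond the scatter); a number 16 percentage points higher from compound 2 to compound 4 (beyond the scatter)). It still falls well short of piperidin-4-yl (a number 45 percentage points lower from compound 1 to compound 4 (beyond the scatter)), so carrying a nitrogen in a non-aromatic ring is not enough on its own to match compound 1. No available evidence bears on this result. Still open, going by these compounds, is whether a piperidine in place of the pyrrolidine on the same hydroxypropyl chain would raise the number. On these data alone, the effect of removing the hydroxyl group from that chain also remains unknown.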